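Nitrooxy on the aryl sulfonamide: expected cytotoxicity of compound 4

This account rests on a few compounds, and the source may have more. Where it says the series, first, only, none or still open, it means among the compounds named here.

Measured compounds:
- compound 1, `O=C1/C(=C/c2ccccc2F)CN(S(=O)(=O)c2ccc(F)cc2)C/C1=C\c1ccccc1F`, 8000 nM
- compound 2, `N#Cc1ccc(S(=O)(=O)N2C/C(=C\c3ccccc3F)C(=O)/C(=C/c3ccccc3F)C2)cc1`, 16500 nM
- compound 3, `O=C1/C(=C/c2cccc(F)c2)CN(S(=O)(=O)c2ccccc2)C/C1=C\c1cccc(F)c1`, 3400 nM

In a functional assay on HepG2 cells (Homo sapiens) for cytotoxicity, read by MTT assay, with a stated time of 24 h (a higher number here means a weaker inhibitor, a lower number a stronger inhibitor), compound 3 gives the lowest of the three numbers; compound 1 gives 8000 nM and compound 2 gives 16500 nM, both higher by more than the scatter. Compound 4, `O=C1/C(=C/c2cccc(F)c2)CN(S(=O)(=O)c2ccc(O[N+](=O)[O-])cc2)C/C1=C\c1cccc(F)c1`, has not yet been measured in this assay. It differs from compound 3 by nitrooxy in place of hydrogen on an aromatic carbon.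

Among the compounds with values here, only one measured step bears on a change at this place. It is a 2.1-fold higher number from compound 1 to compound 2 (0.31 log units; beyond the scatter), a different replacement on a six-membered aromatic ring of carbon only, para to a large group, and it moved the number only modestly. Within the data shown here, no measured pair carries a nitrooxy group, so the size of the step from compound 3 to compound 4 has no close precedent. Among the measured compounds shown here, on the one step available, a change at this position is expected to shift this assay by at most a modest amount, and the direction of the step from compound 1 to compound 2 suggests a somewhat higher number rather than a lower one.

For compound 4 the estimate is 4500 nM, with a range of 1700 nM to 12000 nM, meaning an expected step of a 1.3-fold higher number from compound 3 to compound 4 (0.12 log units; within the scatter).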

Compound 4, half-maximal inhibitory concentration: 8100 nM
Compound 4: the middle estimate sits 1.8-fold (0.26 log units) below what was measured; the measured number falls inside the stated range.
By their numbers in this assay, from the lowest: compound 3; then compounds 1 and 4 (each within the scatter of the next); then compound 2.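

In this assay, the change from phenyl to 4-(nitrooxy)phenyl gives a 2.4-fold higher number from compound 3 to compound 4 (0.38 log units; beyond the scatter), so replacing hydrogen at this place, on an aromatic carbon para to a large group, moves the number beyond the scatter. The earlier compounds shown here offered only an exchange of one substituent for another, cyano in place of fluoro, with a 2.1-fold higher number from compound 1 to compound 2 (0.31 log units; beyond the scatter); the new step shows that adding a nitrooxy group of 4 heavy atoms to an unsubstituted position also gives a modest rise, on a core with its fluoro groups placed differently, and these two steps are the only ones available at this place, with neither going against the rise. Nothing available gives a reason for the rise at this place.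

The compounds shown leave open whether the rise belongs to nitrooxy itself or would also follow from a hydroxy group, an amine or a carboxylic acid at the same place. They also leave open whether nitrooxy in place of hydrogen would give a step of similar size and direction on the core of compound 1.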